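The source may report more compounds than this note shows. Statements on the series, on what has been measured and on what is new or still open speak of the compounds shown alone.

Compound 1 `COc1ccc(CN(C(=O)CSC(=S)N2CCN(C(=O)OC(C)(C)C)CC2)c2ccc(Br)cc2)cc1` carries a bromo group on the first core. In a functional assay on MGC-803 cells (Homo sapiens) for inhibition, read by CCK-8 assay, with a stated time of 48 h (on this read-out lower numbers stand for stronger inhibition and higher numbers for weaker inhibition), compound 1 returns only a limit of the assay, > 20000 nM. Compound 2 `COc1ccc(CN(C(=O)CSC(=S)N2CCN(C(=O)OC(C)(C)C)CC2)c2ccc(C)cc2)cc1` differs from it by methyl in place of bromo on an aromatic carbon. In this assay compound 2 likewise returns only a limit, > 20000 nM. The step that the two limits leave unreadable from compound 1 to compound 2 therefore has no readable size, because both values sit at the limit of > 20000 nM in this assay, at which 2 of the 3 values shown sit.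

Compound 3 `COc1cc(N(Cc2ccc(Br)cc2)C(=O)CSC(=S)N2CCN(C(=O)OC(C)(C)C)CC2)cc(OC)c1OC` rests on a second core; the difference between the two cores is not broken down here. In this assay compound 3 gives 12400 nM. Within the data shown here, this is the only plain number among the values so far; what compound 1 and compound 2 return are limits of the assay.

Compound 4 `COc1cc(N(Cc2ccc(C)cc2)C(=O)CSC(=S)N2CCN(C(=O)OC(C)(C)C)CC2)cc(OC)c1OC` is not yet measured and differs from compound 3 by methyl in place of bromo on an aromatic carbon, the same change as that from compound 1 to compound 2, with the place described in the same words. Since the earlier step that the two limits leave unreadable from compound 1 to compound 2 gives no size to lean on, the step from compound 3 to compound 4 is expected to stay within the usual scatter, a 1.1-fold higher number from compound 3 to compound 4 (0.05 log units; within the scatter). Compound 4 is accordingly expected near 14000 nM in this assay, between 5000 nM and 40000 nM, with a fair chance that only a limit is reported.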

Compound 4, half-maximal inhibitory concentration: 16700 nM
Beside the measured number, compound 4's estimate is 1.2-fold (0.08 log units) below it; the range from low to high includes it.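

In this assay, methyl in place of bromo gives a 1.3-fold higher number from compound 3 to compound 4 (0.13 log units; within the scatter), so on the core of compound 3 this change leaves the number within the usual scatter. On the core of compound 1 the same change cannot be read, because compound 1 and compound 2 both return only a limit of the assay: the limit of > 20000 nM in this assay, at which 2 of the 4 values shown sit. The series therefore offers one readable step and no second size to set against it, so the result neither supports nor rules out the change behaving alike on both cores.

Open, on these data alone, is whether an amine or a carboxylic acid in the place held by bromo and methyl, on an aromatic carbon para to a large group, would move the number on the core of compound 3 beyond the scatter. Also open, as far as these compounds go, is whether any such group would bring the core of compound 1 to a plain number in this assay.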